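This account rests on a few compounds, and the source may have more. Where it says the series, first, only, none or still open, it means among the compounds named here.

Measured in a functional assay on HL-60 cells (Homo sapiens) for inhibition, read by trypan blue exclusion, with a stated time of 72 h; a higher number here means a weaker inhibitor of growth, a lower number a stronger inhibitor of growth:

- compound 1 `C=C(CC)C(=O)c1ccc(OCc2nc(-c3ccc([N+](=O)[O-])cc3)cs2)c(C)c1C`: 3600 nM
- compound 2 `C=C(CC)C(=O)c1ccc(OCc2nc(-c3ccc(C(F)(F)F)cc3)cs2)c(C)c1C`: 1500 nM
- compound 3 `C=C(C)C(=O)c1ccc(OCc2nc(-c3ccc([N+](=O)[O-])cc3)cs2)cc1Cl`: 5900 nM

Compound 1 and compound 2 share a core and differ only by trifluoromethyl in place of nitro on an aromatic carbon; this change gave a 2.4-fold lower number from compound 1 to compound 2 (0.38 log units; beyond the scatter). Compound 3 carries the other core; how the two cores differ is not broken down here, and compound 3 in this assay stands within the scatter of compound 1 while lying beyond it from compound 2.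

Compound 4 `C=C(C)C(=O)c1ccc(OCc2nc(-c3ccc(C(F)(F)F)cc3)cs2)cc1Cl` is not yet measured. It differs from compound 3 by trifluoromethyl in place of nitro on an aromatic carbon, the same change as between compound 1 and compound 2. The expectation for compound 4 in this assay therefore rests on one earlier instance only, and a step of similar size is expected, a 2.4-fold lower number from compound 3 to compound 4 (0.37 log units; beyond the scatter), because compound 3 gives 5900 nM and the earlier change gave a 2.4-fold lower number from compound 1 to compound 2 (0.38 log units; beyond the scatter). Compound 4 is estimated at 2500 nM, with a range from 1200 nM to 5500 nM.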

Compound 4, concentration for 50% growth inhibition: 1400 nM
Beside the measured number, compound 4's estimate is 1.8-fold (0.25 log units) above it, within the range that was stated.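

In this assay trifluoromethyl in place of nitro gives a 4.2-fold lower number from compound 3 to compound 4 (0.62 log units; beyond the scatter) and so points the same way on both cores. The size of the step does not separate the two cores: the same change on two cores in this assay, a 2.4-fold lower number (0.38 log units; beyond the scatter) from compound 1 to compound 2 and a 4.2-fold lower number (0.62 log units; beyond the scatter) from compound 3 to compound 4, 1.8-fold (0.24 log units) apart, within the scatter of two such steps
Two instances show that the change carried over between these two cores in this assay, but they do not show that it would carry over to any other core, and they give no reason for the step.

Open, going by these compounds, is whether other groups at this place, such as a nitrile, an amine or a carboxylic acid, would give a step of similar size. Also open is which of the differences between the two cores bears on the values, as no pair shown separates them.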